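Ester in place of morpholine amide: compound 4 in the series

The source may report more compounds than this note shows. Statements on the series, on what has been measured and on what is new or still open speak of the compounds shown alone.

In a functional assay on MCF7 cells (Homo sapiens) for inhibition, read by sulforhodamine B assay, with a stated time of 72 h (a higher number here means a weaker inhibitor of growth, a lower number a stronger inhibitor of growth), compound 1 `O=C(O)/C=C/c1ccncc1-c1ccc2cc[nH]c2c1` gives > 10000 nM.
Compound 2 `NC(=O)/C=C/c1ccncc1-c1ccc2ccccc2c1` gives > 10000 nM.
Compound 3 `O=C(/C=C/c1ccncc1-c1ccc2cc[nH]c2c1)N1CCOCC1` gives > 10000 nM.

Each of these values is a limit of this assay and not a number. Compound 3 stands at the limit of > 10000 nM in this assay, at which 3 of the 3 values shown sit, together with the two others, so its true position is not known. Among the compounds with values here, the one step, a step that the two limits leave unreadable from compound 1 to compound 3, has a limit at both ends and reads as nothing more than that.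

Compound 4 `CCOC(=O)/C=C/c1ccncc1-c1ccc2cc[nH]c2c1` differs from compound 3 by ethoxy in place of morpholin-4-yl on a carbonyl carbon. Within the data shown here, no measured step bears on this change. With all three values resting at the limit, compound 4 is expected to return the same limit, and the step that the limit leaves unreadable from compound 3 to compound 4 is expected to be none beyond the scatter. Compound 4 is estimated at 15000 nM, within 5000 nM to 60000 nM.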

Compound 4, concentration for 50% growth inhibition: 6880 nM
Compound 4: the middle estimate sits 2.2-fold (0.34 log units) above what was measured, within the range that was stated.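

In this assay, within the data shown here, compound 4 gives 6880 nM as the first number and not a limit, so a change on this carbonyl carbon can now be read from one side. Ethoxy in place of morpholin-4-yl gives an at least 1.4-fold lower number from compound 3 to compound 4 (0.16 log units; that floor lies within the scatter) and ethyl in place of hydrogen on an oxygen next to a carbonyl group gives an at least 1.4-fold lower number from compound 1 to compound 4 (0.16 log units; that floor lies within the scatter) as floors only, so the true size of either step stays unknown. The other values remain limits of the assay: the limit of > 10000 nM in this assay, at which 3 of the 4 values shown sit.

As far as these compounds go, whether a longer chain such as butoxy, or an amine, on this carbonyl carbon would carry the number beyond the scatter stays open. Also open, from the compounds shown here alone, is whether ethoxy would give a number on the core of compound 2.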